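A few compounds are considered here, and "the series" means these few. Any claim that something is new, unique, unknown or untested is made for them only; others in the source may bear on it.

Measured compounds and their results:

Compound 1, `O=C(COc1ccc(F)cc1)Nc1nc(-c2ccc(Br)cc2)cs1`, gives 51700 nM in a functional assay on A549 cells (Homo sapiens) for cytotoxicity, read by trypan blue exclusion, with a stated time of 48 h; a higher number here means a weaker inhibitor, a lower number a stronger inhibitor.
Compound 2, `Cc1ccc(-c2csc(NC(=O)COc3ccc(F)cc3)n2)cc1`, gives 19100 nM in this assay.
Compound 3, `Cc1ccc(OCC(=O)Nc2nc(-c3ccc(C)cc3)cs2)cc1`, gives 48800 nM in this assay.

Compound 2 and compound 1 share one core and differ by one change: bromo in place of methyl on an aromatic carbon. That change made a step of a 2.7-fold higher number from compound 2 to compound 1 (0.43 log units; beyond the scatter), so the bromo-bearing compound stands as the weaker inhibitor of the pair by a modest but real margin.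

Compound 4, `Cc1ccc(OCC(=O)Nc2nc(-c3ccc(Br)cc3)cs2)cc1`, is not yet measured. It is built from compound 3 by the same change, (bromo in place of methyl on an aromatic carbon), at the same kind of place on the ring. The core of compound 3 is not the core of compound 2, though; the two cores differ by methyl in place of fluoro on an aromatic carbon, which itself made a step of a 2.6-fold higher number from compound 2 to compound 3 (0.41 log units; beyond the scatter). Compound 3 and compound 1 lie within the usual scatter of each other, so no order can be read between them.

Among the measured compounds shown here, the only guide to what the bromo-for-methyl change does is the single step seen between compound 2 and compound 1. Taking that step as the model, compound 4 is expected to show a step of a 2.3-fold higher number from compound 3 to compound 4 (0.35 log units; beyond the scatter), resting on a 2.7-fold higher number from compound 2 to compound 1 (0.43 log units; beyond the scatter) as the sole precedent. Compound 4 is thus estimated at 110000 nM in this assay, with a plausible range from 50000 nM to 250000 nM, and with some chance that so weak an inhibitor is reported only as a limit.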

Compound 4, half-maximal inhibitory concentration: 58600 nM
Beside the measured number, compound 4's estimate is 1.9-fold (0.27 log units) above it, and the stated range covers the measured number.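

In this assay, replacing 4-methylphenyl with 4-bromophenyl on the second core gave a 1.2-fold higher number from compound 3 to compound 4 (0.08 log units; within the scatter), a step too small to read as a real change, and it cannot be told apart from the larger step seen earlier for the same swap: the same change on two cores in this assay, a 2.7-fold higher number (0.43 log units; beyond the scatter) from compound 2 to compound 1 and a 1.2-fold higher number (0.08 log units; within the scatter) from compound 3 to compound 4, 2.3-fold (0.35 log units) apart, within the scatter of two such steps. The other change seen on two cores, methyl in place of fluoro on an aromatic carbon, gave a 1.1-fold higher number from compound 1 to compound 4 (0.05 log units; within the scatter), and this step also cannot be told apart from its earlier counterpart: the same change on two cores in this assay, a 2.6-fold higher number (0.41 log units; beyond the scatter) from compound 2 to compound 3 and a 1.1-fold higher number (0.05 log units; within the scatter) from compound 1 to compound 4, 2.3-fold (0.35 log units) apart, within the scatter of two such steps. Among the compounds shown here, one step of each pair lies beyond the scatter and the other within it, but with only two steps per change, these compounds neither show that a change keeps the same size from one core to another nor show that the core alters it.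

As far as these compounds go, every substituent on the two outer rings here is fluoro, methyl or bromo, so it remains open how a methoxy group, a nitrile or an amine would behave in these places. The compounds also leave open what a longer chain would do in place of the short link that joins the oxygen to the amide carbonyl.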